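Chloro in Place of Methylsulfanyl on a Shared Core

This account rests on a few compounds, and the source may have more. Where it says the series, first, only, none or still open, it means among the compounds named here.

The account starts from compound 1 `CSc1ccc(NC(=O)Nc2cc(C)nc3ccccc23)cc1`, whose core is shared by every compound here. For the measured compounds named here, in an ADME assay on HepG2 cells (Homo sapiens) for cytotoxicity, with a stated time of 72 h (on this read-out lower numbers stand for an effect already at smaller amounts and higher numbers for an effect only at larger amounts of compound), compound 1 gives 16000 nM, the only number among the three values reported. Compound 2 `Cc1cc(NC(=O)Nc2cccc(C(N)=O)c2)c2ccccc2n1` reaches only a limit of this assay, > 25000 nM. Compound 3 `Cc1cc(NC(=O)Nc2cc(F)cc(F)c2)c2ccccc2n1` likewise stops at a limit, > 25000 nM. Two of the three values thus rest at the limit of > 25000 nM in this assay, at which 2 of the 3 values shown sit. Compound 4 `Cc1cc(NC(=O)Nc2ccc(Cl)cc2)c2ccccc2n1` has not yet been measured; it differs from compound 1 by chloro in place of methylsulfanyl on an aromatic carbon. Going by the values given here, with no measured step between compounds to guide the size of this change, compound 4 is expected to show a 1.3-fold higher number from compound 1 to compound 4 (0.10 log units; within the scatter), a small shift toward larger amounts that may not exceed the usual scatter. Compound 4 is therefore estimated at 20000 nM, within a range from 8000 nM to 50000 nM.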

Compound 4, half-maximal effective concentration: > 25000 nM
Compound 4: a limit, no number; the forecaster's own chance of this, stated with the estimate: 45%; middle value at least 1.2-fold (0.09 log units) from the limit.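

For the compounds shown here, at this position, on an aromatic carbon para to a large group, chloro in place of methylsulfanyl gives the first measured step on the shared core in this assay: an at least 1.5-fold higher number from compound 1 to compound 4 (0.19 log units; that floor lies within the scatter). Compound 4 stops at a limit, so only the floor of this step can be read, not its size. Compound 1 remains the only compound here with a number: the limit of > 25000 nM in this assay, at which 3 of the 4 values shown sit.

Going by these compounds, whether an amine or a carboxylic acid at this position would give a number or stop at the same limit stays open. The compounds shown also leave open whether this step goes past the usual scatter.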